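The source may report more compounds than this note shows. Statements on the series, on what has been measured and on what is new or still open speak of the compounds shown alone.

Working notes on the series. Compound 1 `CCOC(=O)c1c(N)sc(/N=C/c2ccc(OC)cc2)c1C(=O)OCC` and compound 2 `CCOC(=O)c1c(N)sc(/N=C/c2ccncc2)c1C(=O)OCC` share one core and differ only in the aryl group on the carbon with a double bond to nitrogen. In a functional assay on Ishikawa cells (Homo sapiens) for inhibition, read by MTT assay, with a stated time of 48 h (a lower number here means a stronger inhibitor, a higher number a weaker inhibitor), compound 1 gives 108000 nM, and compound 2 gives 119000 nM. For the measured compounds named here, compound 2 thus carries the highest of the two numbers measured so far, with compound 1 as its nearest neighbour; the step of a 1.1-fold higher number from compound 1 to compound 2 (0.04 log units; within the scatter) stays within the scatter, so the two read as equivalent.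

Compound 3 `CCOC(=O)c1c(N)sc(/N=C/c2ccc(C)cc2)c1C(=O)OCC` has not yet been run in this assay. It departs from compound 2 as follows: 4-methylphenyl in place of pyridin-4-yl on a carbon with a double bond to nitrogen. Going by the values given here, the only measured step bearing on this exchange is a 1.1-fold higher number from compound 1 to compound 2 (0.04 log units; within the scatter), where swapping one para-substituted phenyl for pyridin-4-yl left the number unchanged within the scatter. Reverting to a carbon-only ring bearing a 4-methyl group is therefore expected to give a step of about a 1.1-fold lower number from compound 2 to compound 3 (0.03 log units; within the scatter), that is none beyond the scatter, in either direction. For compound 3 in this assay the estimate is 110000 nM, with a range from 50000 nM to 250000 nM.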

Compound 3, half-maximal inhibitory concentration: 52500 nM
For compound 3 the middle estimate is 2.1-fold (0.32 log units) above the measured one; the range from low to high includes it.
By their numbers in this assay, from the lowest: compound 3; then compounds 1 and 2 (each within the scatter of the next).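

In this assay, the aryl group on the carbon with a double bond to nitrogen proves able to shift the number: there is a 2.3-fold lower number from compound 2 to compound 3 (0.36 log units; beyond the scatter), and there is also a 2.1-fold lower number from compound 1 to compound 3 (0.31 log units; beyond the scatter), both modest but beyond the scatter, which the earlier step between compound 1 and compound 2 did not show. The second of these steps keeps the carbon-only ring and exchanges only methoxy for methyl on an aromatic carbon, so the shift does not depend on replacing pyridin-4-yl. No simple split between pyridin-4-yl and carbon-only rings fits the three compounds, since compound 1 carries a carbon-only ring yet stays within the scatter of compound 2, and only compound 3 stands apart.

On these data alone, it remains open whether an ethyl chain in place of the methyl of 4-methylphenyl, or an amine on that ring, would take the number lower still or return it to the level of compound 1 and compound 2. Nothing available bears on what lies behind the shift seen with compound 3.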